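A few compounds are considered here, and "the series" means these few. Any claim that something is new, unique, unknown or untested is made for them only; others in the source may bear on it.

Series notes. Compound 1 `C=C(Br)C(=O)Nc1cccc(-c2cn3nc(-c4ccccc4)sc3n2)c1` and compound 2 `C=C(Br)C(=O)Nc1cccc(-c2cn3nc(-c4ccc(C)cc4)sc3n2)c1` carry a (1-bromoethenyl)carbonyl amide; compound 3 `Nc1cccc(-c2cn3nc(-c4ccccc4)sc3n2)c1` and compound 4 `Cc1ccc(-c2nn3cc(-c4cccc(N)c4)nc3s2)cc1` carry the free amino group instead. In a functional assay on L1210 cells (Mus musculus) for inhibition, read by cell counting, with a stated time of 2 days (a higher number here means a weaker inhibitor, a lower number a stronger inhibitor), compound 1 gives 600 nM, compound 2 gives 920 nM, and compound 3 gives 32000 nM.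

The difference between compound 1 and compound 2 is methyl in place of hydrogen on an aromatic carbon, and the step it made was a 1.5-fold higher number from compound 1 to compound 2 (0.19 log units; within the scatter). The cores of compound 1 and compound 3 differ by hydrogen in place of (1-bromoethenyl)carbonyl on a nitrogen on an aromatic ring, with the step of a 53-fold higher number from compound 1 to compound 3 (1.73 log units; beyond the scatter).

Compound 4 differs from compound 3 by methyl in place of hydrogen on an aromatic carbon; the place line reads the same as for compound 1 to compound 2, so this is the same change. From compound 3 to compound 4 the expected step is a 1.3-fold higher number from compound 3 to compound 4 (0.12 log units; within the scatter), resting on the step of a 1.5-fold higher number from compound 1 to compound 2 (0.19 log units; within the scatter) in the amide pair. Compound 4 is thus estimated at 42000 nM, with a range of 18000 nM to 95000 nM.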

Compound 4, half-maximal inhibitory concentration: 4800 nM
For compound 4 the middle estimate is 8.8-fold (0.94 log units) above the measured one, outside the stated range (below it).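

In this assay the methyl change does not carry over from the amide pair to the amine pair, with a 6.7-fold lower number from compound 3 to compound 4 (0.82 log units; beyond the scatter) set against the earlier step: the same change on two cores in this assay, a 1.5-fold higher number (0.19 log units; within the scatter) from compound 1 to compound 2 and a 6.7-fold lower number (0.82 log units; beyond the scatter) from compound 3 to compound 4, 10-fold (1.01 log units) apart, beyond the scatter of two such steps. Removal of the (1-bromoethenyl)carbonyl likewise depends on the core, with a 5.2-fold higher number from compound 2 to compound 4 (0.72 log units; beyond the scatter) set against the earlier step: the same change on two cores in this assay, a 53-fold higher number (1.73 log units; beyond the scatter) from compound 1 to compound 3 and a 5.2-fold higher number (0.72 log units; beyond the scatter) from compound 2 to compound 4, 10-fold (1.01 log units) apart, beyond the scatter of two such steps. The two changes are therefore not additive across these four compounds, but this single set of four does not show why, or whether the same holds for other groups.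

Open, from the compounds shown here alone, is whether chloro or methoxy in place of the methyl follows the amide pair or the amine pair. Also open, going by these compounds, is how a plain acetyl on the nitrogen compares with the (1-bromoethenyl)carbonyl on either core.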